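A few compounds are considered here, and "the series" means these few. Any claim that something is new, unique, unknown or untested is made for them only; others in the source may bear on it.

Notes on the series.

Three compounds have numbers in a functional assay on NCI-H460 cells (Homo sapiens) for antiproliferative activity, read by CCK-8 assay, with a stated time of 72 h, tested at 2 uM; on this read-out higher numbers stand for a stronger effect at the one concentration tested and lower numbers for a weaker effect. Compound 1 `CCCCn1cnc2c(Nc3cccc(Cl)c3)nc(NCOCc3ccc(/C=C/C(=O)Nc4ccccc4N)cc3)nc21` gives 25.7%. Compound 3 `Nc1ccccc1NC(=O)/C=C/c1ccc(COCNc2nc(Nc3cccc(Cl)c3)c3ncn(C4CCCC4)c3n2)cc1` gives 37.1%. Compound 2 `CCC(C)n1cnc2c(NCc3ccc(C(=O)Nc4ccccc4N)cc3)nc(Cl)nc21` gives 47.3%, the highest of the three, standing beyond the scatter above compound 3 and further still above compound 1.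

Among the compounds with values here, the one step between two measured compounds that differ in a single place is a number 11.4 percentage points higher from compound 1 to compound 3 (beyond the scatter), a change on the aromatic nitrogen of the shared core.

Compound 4 `CCCn1cnc2c(NCc3ccc(C(=O)Nc4ccccc4N)cc3)nc(Cl)nc21` differs from compound 2 in one place: hydrogen in place of methyl on a saturated chain carbon bound to an aromatic nitrogen and a saturated chain carbon. Within the data shown here, this also sits on the chain carried by the aromatic nitrogen, so the step from compound 1 to compound 3 is the only measured step that bears on it, but that step enlarges the group to a ring, whereas here the chain loses one carbon. Among the measured compounds shown here, no measured pair shows the loss of a methyl from this chain, so the direction is open. For the measured compounds named here, since the only comparable step was modest, the expected step is small, within the scatter, and given the modest gain seen in a number 11.4 percentage points higher from compound 1 to compound 3 (beyond the scatter) a slightly lower number for the smaller chain is estimated, a number 4.3 percentage points lower from compound 2 to compound 4 (within the scatter). Compound 4 is therefore estimated at 43% in this assay, with a range from 30% to 56%.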

Compound 4, a percentage reported as inhibition, at one concentration (the size of the read-out at that concentration, not a potency): 31%
Beside the measured number, compound 4's estimate is 12 percentage points above it, and the stated range covers the measured number.
By their numbers in this assay, from the lowest: compounds 1, 4 and 3 (each within the scatter of the next, the first and the last beyond it); then compound 2.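

In this assay the change from sec-butyl to propyl gives a number 16.3 percentage points lower from compound 2 to compound 4 (beyond the scatter), so the loss of a methyl alone, on a saturated chain carbon bound to an aromatic nitrogen and a saturated chain carbon, is enough to move the number beyond the scatter. The earlier step on this nitrogen, a number 11.4 percentage points higher from compound 1 to compound 3 (beyond the scatter), replaced a straight chain with a ring, whereas this pair isolates a change within the chain itself and shows that the group here matters on a second form of the compounds as well. In both pairs the straight chain gives the lower number, although that pattern rests on these two pairs alone, and nothing available accounts for the step.

Going by these compounds, whether the loss of this methyl would give a step in the same direction on the core of compound 1 remains open. Also open, on these data alone, is how an isopropyl, a tert-butyl, a longer chain such as pentyl or a hydroxyethyl group on this nitrogen would read, and therefore whether the number tracks the branching, the length of the chain or neither.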